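Adding a Second Chlorine to a Purine Scaffold

The source may report more compounds than this note shows. Statements on the series, on what has been measured and on what is new or still open speak of the compounds shown alone.

Measured compounds:
compound 1 `ClCc1ccccc1Cn1cnc2c(Cl)nc(Cl)nc21` 3310 nM
compound 2 `ClCc1ccccc1Cn1cnc2c(Cl)ncnc21` 5490 nM
compound 3 `ClCc1cccc(Cn2cnc3ncnc(Cl)c32)c1` 3540 nM

All three were tested in a functional assay on SK-MEL-28 cells (Homo sapiens) for cytotoxicity, read by sulforhodamine B assay, with a stated time of 48 h; on this read-out lower numbers stand for stronger inhibition of growth and higher numbers for weaker inhibition of growth. Compound 2 and compound 1 differ by chloro in place of hydrogen on an aromatic carbon, and that step gave a 1.7-fold lower number from compound 2 to compound 1 (0.22 log units; within the scatter). Compound 3 shares its atoms with compound 2 but joins them differently; the difference between the two cores is not broken down here. In this assay compound 3 and compound 1 give numbers that lie within the scatter of each other.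

Compound 4 `ClCc1cccc(Cn2cnc3nc(Cl)nc(Cl)c32)c1` has not yet been measured. It differs from compound 3 by chloro in place of hydrogen on an aromatic carbon, the same change that turns compound 2 into compound 1. Resting on that earlier step, compound 4 is expected to show a 1.5-fold lower number from compound 3 to compound 4 (0.19 log units; within the scatter), since the change is made on the same place of the shared core. Compound 4 is therefore estimated at 2300 nM, with a likely range from 1200 nM to 4500 nM.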

Compound 4, concentration for total growth inhibition: 400 nM
For compound 4 the middle estimate is 5.8-fold (0.76 log units) above the measured one; the whole stated range lies above it.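

In this assay, placing the chloro group on the core of compound 3 gave an 8.9-fold lower number from compound 3 to compound 4 (0.95 log units; beyond the scatter), a clear gain in growth inhibition. The same change did not have the same size of effect on the two cores: the same change on two cores in this assay, a 1.7-fold lower number (0.22 log units; within the scatter) from compound 2 to compound 1 and an 8.9-fold lower number (0.95 log units; beyond the scatter) from compound 3 to compound 4, 5.3-fold (0.73 log units) apart, beyond the scatter of two such steps. So in this series, the step measured on one core was a poor guide to the step on the other, but two pairs cannot explain the gap or predict the step on a further core.

On these data alone, it remains open whether an amine or a methoxy group on the carbon between two ring nitrogen atoms would act like chloro. As far as these compounds go, whether such a group would also differ between the two cores is equally open.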